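The source may hold more compounds than are shown below. What is called first, only, known or untested is meant among the compounds shown, and "the series" means these compounds.

For the measured compounds named here, in a functional assay on HT-29 cells (Homo sapiens) for inhibition, read by sulforhodamine B assay, with a stated time of 72 h (a higher number here means a weaker inhibitor, a lower number a stronger inhibitor), only two compounds have been measured so far. Compound 1 (`C=CC1C(=O)N(c2cc(OC)c(OC)c(OC)c2)C1c1ccc(SC)cc1`) gives 113 nM, and compound 2 (`CCSc1ccc(C2CC(=O)N2c2cc(OC)c(OC)c(OC)c2)cc1`) gives 311 nM. Compound 2 therefore has the higher of the two numbers, making it the weaker inhibitor by a gap beyond the usual scatter. Going by the values given here, no pair of measured compounds differs in one place only, so the effect of any single change remains unmeasured. Compound 3 (`C=CC1C(=O)N(c2cc(OC)c(OC)c(OC)c2)C1c1ccc(SCC)cc1`) departs from compound 2 by one change, vinyl in place of hydrogen on a saturated ring carbon. Compound 1 carries the same vinyl and reads 113 nM, so a modest fall in the number is expected in this assay, though this remains a weak guide. The expected move is a 2.2-fold lower number from compound 2 to compound 3 (0.35 log units; beyond the scatter). For compound 3, the estimated value is 140 nM, within a range of 45 nM to 420 nM.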

Compound 3, half-maximal inhibitory concentration: 257 nM
Compound 3: the middle estimate sits 1.8-fold (0.26 log units) below what was measured; the measured number falls inside the stated range.
By their numbers in this assay, from the lowest: compound 1; then compounds 3 and 2 (each within the scatter of the next).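

In this assay, vinyl in place of hydrogen on a saturated ring carbon of the four-membered non-aromatic ring gives a 1.2-fold lower number from compound 2 to compound 3 (0.08 log units; within the scatter), which is within the scatter, so with the 4-(ethylsulfanyl)phenyl group present this change has no measurable effect on the number. With the vinyl kept, methyl in place of hydrogen on a saturated chain carbon bound to a sulfur gives a 2.3-fold higher number from compound 1 to compound 3 (0.36 log units; beyond the scatter), which is beyond the scatter, so in this pair the small change at the sulfur chain does show in the assay. Nothing available explains either step.

Going by these compounds, whether vinyl would have the same small effect when the sulfur carries methyl rather than ethyl stays open. So does how an amine or hydroxyl on that ring carbon, or a propyl chain on the sulfur, would read.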